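A few compounds are considered here, and "the series" means these few. Any claim that something is new, unique, unknown or untested is made for them only; others in the source may bear on it.

Measured so far:
- compound 1, `CC(C)c1nn(-c2ccc(C(N)=O)c(N[C@H]3CC[C@H](O)CC3)c2)c2nccc(-n3cnc(-c4ccncc4)c3)c12`: 165 nM
- compound 2, `CC(C)c1nn(-c2ccc(C(N)=O)c(N[C@H]3CC[C@H](O)CC3)c2)c2nccc(-n3cnc(-c4ccc(Oc5ccccc5)cc4)c3)c12`: 503 nM

In a functional assay on SK-BR-3 cells (Homo sapiens) for inhibition, read by CellTiter-Glo, with a stated time of 72 h (on this read-out lower numbers stand for stronger inhibition and higher numbers for weaker inhibition), compound 1 gives 165 nM, the lowest of the two numbers. Compound 2 gives 503 nM, a higher number that sits beyond the usual scatter of this assay, so compound 1 is the more potent of the two measured compounds.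

Compound 3, `COc1cncc(-c2ccnc3c2c(C(C)C)nn3-c2ccc(C(N)=O)c(N[C@H]3CC[C@H](O)CC3)c2)c1`, has not been measured in this assay. Compared with compound 1 it carries 5-methoxypyridin-3-yl in place of 4-(pyridin-4-yl)-1H-imidazol-1-yl on an aromatic carbon. Within the data shown here, no step between two measured compounds covers a change of this kind, so there is no measured precedent to draw on; what the two measured numbers show is that the larger appendage of compound 2 goes with the weaker result.

On that basis the step from compound 1 to compound 3 is expected to be small to moderate, most likely toward a higher number, and it may well fall within the scatter; the expected step is a 1.9-fold higher number from compound 1 to compound 3 (0.29 log units; within the scatter). For compound 3 the estimated value in this assay is 320 nM, with a range from 60 nM to 1700 nM.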

Compound 3, half-maximal inhibitory concentration: 451 nM
Compound 3: the middle estimate sits 1.4-fold (0.15 log units) below what was measured, within the range that was stated.
By their numbers in this assay, from the lowest: compound 1; then compounds 3 and 2 (each within the scatter of the next).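

At the aromatic carbon opposite the ring nitrogen, 5-methoxypyridin-3-yl in place of 4-(pyridin-4-yl)-1H-imidazol-1-yl gives a 2.7-fold higher number from compound 1 to compound 3 (0.44 log units; beyond the scatter) in this assay, so this position does respond to a change of group. The earlier link between a larger appendage and a weaker number does not extend into a simple size trend: compound 3 carries a smaller group than compound 1 yet has the higher number, and compound 3 and compound 2 lie within the scatter of each other, so compound 3 goes against any reading that a smaller group does better here. Nothing in the available data accounts for this step.

The change replaces the five-membered aromatic ring and the attached pyridine together and also brings in the methoxy, so the compounds shown do not separate what each of these contributes. A plain pyridin-3-yl would isolate the methoxy, while a 4-phenyl-1H-imidazol-1-yl would test the ring nitrogen of the pyridine in the group of compound 1.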